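The source may hold more compounds than are shown below. What is called first, only, known or untested is meant among the compounds shown, and "the series" means these compounds.

Measured compounds:
- compound 1 `COc1cc(/C=C/C(=O)c2cccc(N=[N+]=[N-])c2)ccc1O`: 7110 nM
- compound 2 `C=C(C)c1cn(-c2cccc(C(=O)/C=C/c3ccc(O)c(OC)c3)c2)nn1`: 9790 nM

In a functional assay on RAW264.7 cells (Mus musculus) for inhibition, with a stated time of 4 days (a lower number here means a stronger inhibitor, a higher number a weaker inhibitor), compound 1 gives 7110 nM, and compound 2 gives 9790 nM. For the measured compounds named here, these are the only two numbers, and they sit close together: the step of a 1.4-fold higher number from compound 1 to compound 2 (0.14 log units; within the scatter) keeps both within the scatter of each other, so neither can be called the stronger or the weaker inhibitor.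

Compound 3 `COc1cc(/C=C/C(=O)c2cccc(-n3cc(-c4ccc(F)cc4)nn3)c2)ccc1O` is the next compound. It differs from compound 2 in one place: 4-fluorophenyl in place of 1-methylethenyl on an aromatic carbon. Going by the values given here, no measured step tests this kind of change. Among the compounds with values here, the single step on record, a 1.4-fold higher number from compound 1 to compound 2 (0.14 log units; within the scatter), replaced the whole group on that side of the shared core without moving the number beyond the scatter, which offers little reason to expect a large step now. The expected step is therefore a 1.2-fold lower number from compound 2 to compound 3 (0.09 log units; within the scatter), no firm direction. Compound 3 is estimated at 8000 nM, within the range 3000 nM to 25000 nM.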

Compound 3, half-maximal inhibitory concentration: 6450 nM
Beside the measured number, compound 3's estimate is 1.2-fold (0.09 log units) above it, and the stated range covers the measured number.
By their numbers in this assay, from the lowest: compounds 3, 1 and 2 (each within the scatter of the next).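

On the aromatic carbon of the five-membered aromatic ring with 3 nitrogen, putting 4-fluorophenyl in place of 1-methylethenyl gives a 1.5-fold lower number from compound 2 to compound 3 (0.18 log units; within the scatter) in this assay. Compound 1 to compound 2 replaced azido with the whole substituted ring, whereas this step varies only the group on that carbon: a group of 7 heavy atoms with a ring enters, one of 3 heavy atoms with no ring leaves, and the two numbers remain within the scatter of each other. No measured information bears on the reason for this result.

From the compounds shown here alone, whether an amine, a carboxylic acid or a longer chain such as hexyl on that carbon would give a step beyond the scatter remains open. The compounds shown also leave open what happens when the hydroxyl or methoxy group elsewhere on the shared core is changed.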